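Bromo in place of hydrogen on compound 3

The compounds below may be only part of what the source reports. "The series", "measured", "known", "first", "only" and "open" are said of these compounds alone.

Measured in a functional assay on SW-620 cells (Homo sapiens) for antiproliferative activity, read by sulforhodamine B assay, with a stated time of 48 h; a lower number here means a stronger inhibitor, a higher number a weaker inhibitor:
- compound 1 `O=C(CCCCCCN1C(=O)/C(=N\O)c2cc(Br)ccc21)NO`: 290 nM
- compound 2 `O=C(CCCCCCN1C(=O)/C(=N\O)c2cc([N+](=O)[O-])ccc21)NO`: 3390 nM
- compound 3 `CO/N=C1/C(=O)N(CCCCCCC(=O)NO)c2ccccc21`: 730 nM

In this assay, compound 3 at 730 nM holds the middle place, above compound 1 and below compound 2. Compound 4 `CO/N=C1/C(=O)N(CCCCCCC(=O)NO)c2ccc(Br)cc21` differs from compound 3 by bromo in place of hydrogen on an aromatic carbon. Among the compounds with values here, no measured step makes this exact change. The closest evidence is a 12-fold higher number from compound 1 to compound 2 (1.07 log units; beyond the scatter), a large step for nitro in place of bromo on an aromatic carbon, so a ring substituent can shift the number strongly. Compound 1, which carries bromo, gives 290 nM, but it also differs from compound 3 elsewhere. A moderate move to a lower number is expected, though its size is uncertain. The expected change is a 1.8-fold lower number from compound 3 to compound 4 (0.26 log units; within the scatter). The estimate for compound 4 is 400 nM, with an expected range of 140 nM to 1100 nM.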

Compound 4, half-maximal inhibitory concentration: 2320 nM
The estimate for compound 4 lay 5.8-fold (0.76 log units) below the measured number; measured number above the stated range.
By their numbers in this assay, from the lowest: compound 1; then compound 3; then compounds 4 and 2 (each within the scatter of the next).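

In this assay the change of bromo in place of hydrogen on an aromatic carbon, meta to a fused ring and para to a fused ring, gives a 3.2-fold higher number from compound 3 to compound 4 (0.50 log units; beyond the scatter) as a modest rise. Within the data shown here, this is the first reading of this change on its own: the earlier step covered only nitro in place of bromo, and here bromo costs activity relative to hydrogen. Nothing at hand accounts for this rise. Open, going by these compounds, is whether an amine or a carboxylic acid on this aromatic carbon would also raise the number, and whether a longer chain would alter the bromo step.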